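Ring configuration and half-life in acid

The source may report more compounds than this note shows. Statements on the series, on what has been measured and on what is new or still open speak of the compounds shown alone.

Compound 1 `O=C(O)[C@H](CO)NC(=O)[C@H]1C[C@H](O)CN1` and compound 2 `O=C(O)[C@H](CO)NC(=O)[C@@H]1C[C@@H](O)CN1` share all atoms and bonds and differ only in configuration as drawn. In a physicochemical assay for metabolic stability, read by HPLC, with a stated time of 12 h, at pH 1.2 (on this read-out lower numbers stand for a shorter-lived compound and higher numbers for a longer-lived compound), compound 1 gives > 12 h, which is a limit of the assay and not a number. In this assay compound 2 gives > 12 h, likewise a limit and not a number. The step that the two limits leave unreadable from compound 1 to compound 2 cannot be read because of the limit of > 12 h in this assay, at which 2 of the 2 values shown sit. Going by the values given here, compound 2 thus stands at that limit, and the one other value shown stands there too.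

Compound 3 `O=C(O)[C@H](CO)NC(=O)[C@H]1C[C@@H](O)CN1` differs from compound 2 in this way: the two compounds have the same atoms and bonds and differ only in configuration as drawn: 1 of 3 stereo elements differ; a stereocentre at a saturated ring carbon is drawn S in compound 2 and R in compound 3. Among the compounds with values here, the only measured step, a step that the two limits leave unreadable from compound 1 to compound 2, bears on this change because of the fact that compounds 1 and 2 differ only in the configuration as drawn; its size is not readable, and it shows only that two configurations of the shared core both reach the limit. No step beyond the scatter is therefore expected in this assay from this further change of configuration, and a third limit is the likeliest outcome. The expected half-life of compound 3 is 18 h, in the range 6 h to 50 h. The step this estimate means is expected to be a step that the limit leaves unreadable from compound 2 to compound 3.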

Compound 3, half-life: > 12 h
Compound 3 ended at the assay's limit; the forecaster's own chance of this, stated with the estimate: 85%; the middle value does not contradict the limit.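

In this assay compound 3 gives > 12 h, a limit and not a number. No step linking compound 3 with compound 1 or compound 2 can be read, because all three compounds stand at the same limit: the limit of > 12 h in this assay, at which 3 of the 3 values shown sit.

The compounds shown leave open whether these configurations differ at all in half-life in this assay.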